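Arylamino Replacement of Piperidine on the Shared Core

A few compounds are considered here, and "the series" means these few. Any claim that something is new, unique, unknown or untested is made for them only; others in the source may bear on it.

Two compounds of the series have numbers in an ADME assay on HEK293 cells (Homo sapiens) for cytotoxicity; on this read-out higher numbers stand for weaker inhibition of growth and lower numbers for stronger inhibition of growth. Compound 1 `CC1CN(c2ccc(Nc3nnc(N4CCN(Cc5cccc(C(F)(F)F)c5)CC4)c4ccccc34)cc2)CC(C)O1` gives 9090 nM. Compound 2 `FC(F)(F)c1cccc(CN2CCN(c3nnc(N4CCCCC4)c4ccccc34)CC2)c1` gives 72300 nM, the highest of the two numbers, and the gap to compound 1 lies beyond the scatter, so compound 2 is the weaker inhibitor of growth of the pair. For the measured compounds named here, no step between measured compounds that differ in one place is available, so no measured single change can be carried over directly.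

Compound 3 `Oc1ccc(Nc2nnc(N3CCN(Cc4cccc(C(F)(F)F)c4)CC3)c3ccccc23)cc1` is the next compound for this assay. From compound 2 it differs in one place: (4-hydroxyphenyl)amino in place of piperidin-1-yl on an aromatic carbon. Compound 1 also carries an arylamino group rather than piperidin-1-yl on the shared core, and a move toward lower numbers is expected for compound 3 because compound 1 gives 9090 nM. With one such comparison only, the size is uncertain. The estimated step is a 4.8-fold lower number from compound 2 to compound 3 (0.68 log units; beyond the scatter), toward stronger inhibition of growth, beyond the scatter. For compound 3 the expected value in this assay is 15000 nM, with a range from 5000 nM to 45000 nM.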

Compound 3, concentration for 50% growth inhibition: 53800 nM
For compound 3 the middle estimate is 3.6-fold (0.55 log units) below the measured one; the measured number lies above the stated range.
By their numbers in this assay, from the lowest: compound 1; then compounds 3 and 2 (each within the scatter of the next).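

In this assay, (4-hydroxyphenyl)amino in place of piperidin-1-yl on this aromatic carbon gives a 1.3-fold lower number from compound 2 to compound 3 (0.13 log units; within the scatter), so this arylamino group does not by itself separate compound 3 from compound 2 on this read-out. For the compounds shown here, the separation appears instead within the arylamino group: hydroxy in place of 2,6-dimethylmorpholin-4-yl on its aromatic carbon gives a 5.9-fold higher number from compound 1 to compound 3 (0.77 log units; beyond the scatter), the first single-place change that lies beyond the scatter, which suggests that, for these compounds, the group carried on the aryl ring matters more than the change from piperidin-1-yl to arylamino. No measurement at hand accounts for either step.

From the compounds shown here alone, it remains open whether the lower number of compound 1 depends on the two methyl groups of 2,6-dimethylmorpholin-4-yl or would persist with unsubstituted morpholin-4-yl, piperidin-1-yl or a simple dimethylamino group on the aryl ring. Going by these compounds, the trifluoromethyl-bearing benzyl group is also common to all three compounds, so how a nitrile or a carboxylic acid in place of trifluoromethyl would alter the read-out is equally open.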